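The compounds below may be only part of what the source reports. "The series", "measured", "known", "first", "only" and "open" are said of these compounds alone.

In a physicochemical assay for lipophilicity, in phosphate buffer, measured as octanol-water partition, at pH 11.5 (a lower number here means a more polar compound, a higher number a more lipophilic compound), the three measured compounds stand as follows:

Compound 1, `CCCNC(=N)NC(=N)Nc1ccc(Cl)cc1`, gives 2.63.
Compound 2, `CCCCCC/N=C(N)/N=C(\N)Nc1ccc(Cl)cc1`, gives 3.13.
Compound 3, `CCCSc1ccc(NC(=N)NC(=N)NCCCCCCNC(=N)NC(=N)Nc2ccc(SCCC)cc2)cc1`, gives 6.58.

Compound 1 has the lowest number of the three. Compound 2 lies a step above it, beyond the usual scatter, and compound 3 lies far above both, so compound 1 is the most polar of the measured set. Compound 4, `CCOC(=N)NC(=N)Nc1ccc(Cl)cc1`, has not yet been measured. It differs from compound 1 in one place: ethoxy in place of propylamino on a carbon with a double bond to nitrogen. Going by the values given here, no measured pair shows this kind of change, so there is no step to lean on. The change removes one heavy atom and exchanges a hydrogen-bond donor for an acceptor. I expect the step from compound 1 to compound 4 in this assay to be small and downward, at about the edge of the scatter, as a number 0.33 log units lower from compound 1 to compound 4 (beyond the scatter). For compound 4 I therefore estimate 2.3, with a range from 1.7 to 2.9.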

Compound 4, partition coefficient: 2.32
Beside the measured number, compound 4's estimate is 0.02 log units below it; low and high end bracket the measured number.
By their numbers in this assay, from the lowest: compound 4; then compound 1; then compound 2; then compound 3.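

In this assay, going by these compounds alone, this is the first pair in the set that differs in one place only, and ethoxy in place of propylamino on a carbon with a double bond to nitrogen gives a number 0.31 log units lower from compound 1 to compound 4 (beyond the scatter) on the shared core. The change alters several counted features at once, with one heavy atom fewer and a hydrogen-bond acceptor where a hydrogen-bond donor stood, and this single step does not separate them. Nothing measured here gives a reason for the step.

Open, on these data alone, is how much of the step goes with the oxygen in place of the nitrogen and how much with the shorter chain. Ethylamino or propoxy at the same place would divide the change into those two parts, while a longer chain such as hexyloxy would show how far the number moves with the length of the chain.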